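Trimethoxyphenyl analogue in the pyrazoline sulfonamide series

The source may report more compounds than this note shows. Statements on the series, on what has been measured and on what is new or still open speak of the compounds shown alone.

Measured so far:
compound 1 `Cc1cc(O)c(C2=NN(c3ccc(S(N)(=O)=O)cc3)C(c3ccccc3O)C2)cc1Cl` — 11200 nM
compound 2 `Cc1cc(O)c(C2=NN(c3ccc(S(N)(=O)=O)cc3)C(/C=C/c3ccccc3)C2)cc1Cl` — 19800 nM
compound 3 `COc1ccc(C2CC(c3cc(Cl)c(C)cc3O)=NN2c2ccc(S(N)(=O)=O)cc2)cc1OC` — 5460 nM

In a functional assay on IGROV-1 cells (Homo sapiens) for antiproliferative activity, with a stated time of 48 h (on this read-out higher numbers stand for weaker inhibition of growth and lower numbers for stronger inhibition of growth), compound 3 gives the lowest of the three numbers: a 2.1-fold lower number from compound 1 to compound 3 (0.31 log units; beyond the scatter) and a 3.6-fold lower number from compound 2 to compound 3 (0.56 log units; beyond the scatter), both beyond the scatter, whereas a 1.8-fold higher number from compound 1 to compound 2 (0.25 log units; within the scatter) stays within it. Compound 4 `COc1ccc(C2CC(c3cc(Cl)c(C)cc3O)=NN2c2ccc(S(N)(=O)=O)cc2)c(OC)c1OC` differs from compound 3 by methoxy in place of hydrogen on an aromatic carbon. For the measured compounds named here, no measured step touches a single added methoxy; the two steps that end at compound 3 exchange the whole aryl group and say nothing about a further substituent on it. On that basis no change beyond the scatter is expected, and compound 4 is estimated at 5000 nM in this assay, between 2000 nM and 12000 nM. The expected step is a 1.1-fold lower number from compound 3 to compound 4 (0.04 log units; within the scatter).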

Compound 4, concentration for total growth inhibition: 5540 nM
For compound 4 the middle estimate is 1.1-fold (0.04 log units) below the measured one, within the range that was stated.
By their numbers in this assay, from the lowest: compounds 3 and 4 (each within the scatter of the next); then compounds 1 and 2 (each within the scatter of the next).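

In this assay, going from 3,4-dimethoxyphenyl to 2,3,4-trimethoxyphenyl gives a 1.0-fold higher number from compound 3 to compound 4 (0.01 log units; within the scatter), so this aromatic carbon accepts a methoxy group with no change beyond the scatter. The added methoxy leaves the earlier separation from the other two groups in place, with a 3.6-fold lower number from compound 2 to compound 4 (0.55 log units; beyond the scatter) and a 2.0-fold lower number from compound 1 to compound 4 (0.31 log units; beyond the scatter). No evidence on the reason for this result is available.

Only methoxy is shown at this carbon, so an amine, a carboxylic acid or a longer alkoxy chain such as butoxy could give a different result. On these data alone, whether the same tolerance holds in other assays also remains open.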